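Chain methyl removal in a phenoxyphenyl acid series

This account rests on a few compounds, and the source may have more. Where it says the series, first, only, none or still open, it means among the compounds named here.

Measured compounds:
compound 1 `CC#CC(CC(=O)O)c1ccc(OC2CCCC2)cc1` — 114 nM
compound 2 `CC#CC(CC(=O)O)c1ccc(Oc2ncc(Br)cn2)cc1` — 1570 nM
compound 3 `CC(CC(=O)O)c1ccc(Oc2ccc(Cl)cc2Cl)cc1` — 2480 nM

In a functional assay on CHO cells for agonist activity at Free fatty acid receptor 1 (Homo sapiens), read by FLIPR and calcium flux (on this read-out higher numbers stand for an effect only at larger amounts of compound and lower numbers for an effect already at smaller amounts), compound 3 gives 2480 nM, the highest of the three numbers. Compound 2, with 1570 nM, lies within the scatter of compound 3, so no order between the two can be read. Compound 1, with 114 nM, lies beyond the scatter of compound 3 and gives its effect at clearly smaller amounts than compound 3 does.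

Compound 4 `O=C(O)CCc1ccc(Oc2ccc(Cl)cc2Cl)cc1` differs from compound 3 by one change: hydrogen in place of methyl on a saturated chain carbon bound to an aromatic carbon and a saturated chain carbon. For the measured compounds named here, the only step defined among the measured compounds, a 14-fold higher number from compound 1 to compound 2 (1.14 log units; beyond the scatter), concerns the group on the ether oxygen and leaves the chain untouched; compound 2 and compound 3 differ in two places at once and give no single-change step. Going by the values given here, no measured step therefore bears on the removal of the chain methyl, and the expectation for compound 4 rests on the absence of information rather than on a pattern.

The step of a 1.8-fold higher number from compound 3 to compound 4 (0.26 log units; within the scatter) is accordingly expected to stay within the scatter, with a wide range around it. Compound 4 is estimated at 4500 nM in this assay, between 1500 nM and 14000 nM.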

Compound 4, half-maximal effective concentration: 1360 nM
Estimate against measurement, compound 4: 3.3-fold (0.52 log units) above, and the stated range ends above it.
By their numbers in this assay, from the lowest: compound 1; then compounds 4, 2 and 3 (each within the scatter of the next).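

Hydrogen in place of methyl on a saturated chain carbon bound to an aromatic carbon and a saturated chain carbon gives a 1.8-fold lower number from compound 3 to compound 4 (0.26 log units; within the scatter) in this assay. For the compounds shown here, this is the first single-change step at this chain carbon, and the earlier step concerned only the group on the ether oxygen. With the core of compound 3, this read-out therefore does not separate 1-(carboxymethyl)ethyl from 2-carboxyethyl, and the chain methyl shows no measurable contribution here, while no measured information on the compounds bears on why this is so.

The compounds shown leave open whether this holds for other groups on the ether oxygen, as the step rests on a single pair and neither compound 1, with its cyclopentyl group, nor compound 2, with its 5-bromopyrimidin-2-yl group, has a partner differing only at this chain carbon. They also leave open what an ethyl group, a hydroxyl group or an amine on the same chain carbon would give in this assay.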